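The compounds below may be only part of what the source reports. "The series", "measured", "known", "first", "only" and "open" are said of these compounds alone.

Compound 1 `CCCc1c(OC)nc2nc(-c3noc(C)n3)cn2c1C` gives 5 mg/kg in a functional assay on the whole organism with Rattus norvegicus as the target; on this read-out higher numbers stand for an effect only at larger amounts of compound and lower numbers for an effect already at smaller amounts.
Compound 2 `CCc1c(OC)nc2nc(-c3nnc(-c4ccccc4)o3)cn2c1C` reaches only a limit of the assay in this assay, > 50 mg/kg, and no number.
Compound 3 `CCCc1c(OC)nc2nc(-c3nnc(C)o3)cn2c1C` gives 10 mg/kg in this assay.

Among the two numbers that are not limits, compound 3 carries the highest, and its nearest neighbour is compound 1: the step of a 2.0-fold higher number from compound 1 to compound 3 (0.30 log units; within the scatter) lies within the scatter, so the two compounds cannot be told apart on these data. The only limit, (the limit of > 50 mg/kg in this assay, at which 1 of the 3 values shown sits), belongs to compound 2 alone.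

Compound 4 `C/C=C/c1c(OC)nc2nc(-c3nnc(C)o3)cn2c1C` differs from compound 3 in one place: prop-1-en-1-yl in place of propyl on an aromatic carbon. For the measured compounds named here, no measured step touches this chain; the single step seen, a 2.0-fold higher number from compound 1 to compound 3 (0.30 log units; within the scatter), alters a different group and was itself within the scatter. Nothing shown therefore argues for a step beyond the scatter in either direction, and the expectation is the step of no change at the digits printed from compound 3 to compound 4 (within the scatter). Compound 4 is expected to give about 10 mg/kg in this assay, estimated between 3 mg/kg and 30 mg/kg.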

Compound 4, minimum effective dose: > 50 mg/kg
Compound 4: no number, only a limit; the forecaster's own chance of this, stated with the estimate: 15%; middle value at least 5.0-fold (0.69 log units) from the limit.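

The chain on this aromatic carbon matters in this assay: putting prop-1-en-1-yl in place of propyl, which only brings in a double bond outside the aromatic rings, gives an at least 5.0-fold higher number from compound 3 to compound 4 (0.69 log units; beyond the scatter). The only earlier step between compounds differing in one place altered a different group and stayed within the scatter, so this is the first change shown to go beyond it. Compound 4 reaches a limit of the assay rather than a number, so the step gives only a minimum size, and this limit is not unique to it: the limit of > 50 mg/kg in this assay, at which 2 of the 4 values shown sit.

The compounds shown do not say how a longer chain such as butyl or a ring such as cyclopropyl would fare on this carbon. On these data alone, this change is also seen in a single pair, so whether it would have a similar effect with the 5-methyl-1,2,4-oxadiazol-3-yl group of compound 1 stays open.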